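This account rests on a few compounds, and the source may have more. Where it says the series, first, only, none or still open, it means among the compounds named here.

In a functional assay on A549 cells (Homo sapiens) for antiproliferative activity, read by MTT assay, with a stated time of 72 h (a higher number here means a weaker inhibitor, a lower number a stronger inhibitor), compound 1 `COc1cc2ncnc(Nc3cccc(Br)c3)c2cc1OCCCN1CCNCCNCCNCC1` gives 14700 nM, compound 2 `COc1cc2ncnc(Nc3cccc(Cl)c3)c2cc1OCCCN1CCNCCNCCNCC1` gives 27100 nM and compound 3 `COc1cc2ncnc(Nc3cccc(Br)c3)c2cc1OCCCN1CCNCCNCC1` gives 34300 nM. Compound 3 sits level with compound 2 within the scatter and beyond the scatter from compound 1. Compound 4 `COc1cccc(Nc2ncnc3cc(OC)c(OCCCN4CCNCCNCC4)cc23)c1` differs from it by methoxy in place of bromo on an aromatic carbon. The closest measured change is a 1.8-fold higher number from compound 1 to compound 2 (0.27 log units; within the scatter), chloro in place of bromo, which stays within the scatter. The ring change, a 2.3-fold higher number from compound 1 to compound 3 (0.37 log units; beyond the scatter), is modest and sets only the starting level. For the measured compounds named here, no measured compound carries this methoxy, so in this assay no step beyond the scatter is expected, and no direction is firm. The estimated change is a 1.1-fold higher number from compound 3 to compound 4 (0.04 log units; within the scatter). Compound 4 is expected at 38000 nM, within 18000 nM to 80000 nM.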

Compound 4, half-maximal inhibitory concentration: > 50000 nM
Compound 4: no number, only a limit; the forecaster's own chance of this, stated with the estimate: 10%; at least 1.3-fold (0.11 log units) between middle value and limit.
By their numbers in this assay, from the lowest: compounds 1, 2 and 3 (each within the scatter of the next, the first and the last beyond it). At a limit, above all of these: compound 4.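

Working from this assay, methoxy in place of bromo on the six-membered aromatic ring gives an at least 1.4-fold higher number from compound 3 to compound 4 (0.16 log units; that floor lies within the scatter). For compound 4, > 50000 nM is a limit, not a number. This position now has a hydrogen-bond acceptor among its groups, with no sign of a gain over bromo, while the true size of the step stays unread: the limit of > 50000 nM in this assay, at which 1 of the 4 values shown sits.

The compounds shown leave open how an amine or a hydroxyl would read at this position. Also open, going by these compounds, is how 3-methoxyphenyl would read with the ring of compound 1.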